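Trimming One Methoxy Group from Compound 2

The source may report more compounds than this note shows. Statements on the series, on what has been measured and on what is new or still open speak of the compounds shown alone.

Compound 2 `COc1cc(-c2cc(/C=C/C(=O)c3ccc(N)cc3)[nH]n2)cc(OC)c1OC` carries three methoxy groups on one of its aromatic rings. Among the measured compounds shown here, in a functional assay on 786-0 cells (Homo sapiens) for inhibition, read by sulforhodamine B assay, with a stated time of 48 h (on this read-out higher numbers stand for weaker inhibition of growth and lower numbers for stronger inhibition of growth), compound 2 gives 6490 nM, the second highest of the three numbers measured so far. Compound 1 `COc1ccc(-c2cc(/C=C/C(=O)c3ccc(N)cc3)[nH]n2)cc1`, which has a single methoxy group on that ring, gives 5690 nM in this assay, a number within the scatter of compound 2. For the measured compounds named here, compound 3 `COc1cc(-c2cc(/C=C/C(=O)c3ccc(F)c(F)c3)[nH]n2)cc(OC)c1OC` gives 15700 nM in this assay; the only measured single-point step is a 2.4-fold higher number from compound 2 to compound 3 (0.38 log units; beyond the scatter), and it concerns the ring attached to the carbonyl, not the methoxy groups.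

Compound 4 `COc1ccc(-c2cc(/C=C/C(=O)c3ccc(N)cc3)[nH]n2)cc1OC` differs from compound 2 by hydrogen in place of methoxy on an aromatic carbon. Going by the values given here, no measured step touches this change directly; the values of compound 1 and compound 2 show that going from three methoxy groups to one leaves the number within the scatter. Compound 4 sits between them in this respect, so the step is expected to be a 1.1-fold lower number from compound 2 to compound 4 (0.03 log units; within the scatter), nothing beyond the scatter. Compound 4 is therefore estimated at 6000 nM in this assay, with a range from 2500 nM to 14000 nM.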

Compound 4, concentration for total growth inhibition: 4390 nM
Compound 4: the middle estimate sits 1.4-fold (0.14 log units) above what was measured; the measured number falls inside the stated range.
By their numbers in this assay, from the lowest: compounds 4, 1 and 2 (each within the scatter of the next); then compound 3.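

Compounds 1 and 2 differ in more than one place, but compound 4 now gives a single-place reading of each methoxy change on this ring in this assay. Hydrogen in place of methoxy on an aromatic carbon, ortho to a methoxy group and meta to a methoxy group, gives a 1.5-fold lower number from compound 2 to compound 4 (0.17 log units; within the scatter) and the other single change, methoxy in place of hydrogen on an aromatic carbon, gives a 1.3-fold lower number from compound 1 to compound 4 (0.11 log units; within the scatter) so among these three compounds neither change can be told apart from the usual scatter. No supporting measurement is available to interpret this result.

The compounds shown leave open whether a hydroxyl group, an ethoxy group or a fluorine atom at this place would move the number beyond the scatter. They also leave open whether the same methoxy change would read alike with the 3,4-difluorophenyl group of compound 3 on the carbonyl.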